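Swapping a methyl for a fluorophenyl on a pyrazole urea

The source may report more compounds than this note shows. Statements on the series, on what has been measured and on what is new or still open speak of the compounds shown alone.

Compound 1, with the structure `Cn1nc(C(C)(C)C)cc1NC(=O)Nc1cc(C(F)(F)F)cc(C(F)(F)F)c1`, was tested in an assay on isolated protein for inhibition of STE20-like serine/threonine-protein kinase (Homo sapiens), read by thermal shift assay, tested at 10 uM (on this read-out higher numbers stand for stronger stabilisation of the target against heat and lower numbers for weaker stabilisation of the target), and there compound 1 gave 2.4 degrees C. Compound 2, with the structure `CC(C)(C)c1cc(NC(=O)Nc2cc(C(F)(F)F)cc(C(F)(F)F)c2)n(-c2ccc(F)cc2)n1`, differs from it in one place:

4-fluorophenyl in place of methyl on an aromatic nitrogen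

In this assay compound 2 gave 0.5 degrees C. This change produced a shift of a number 1.9 degrees C lower from compound 1 to compound 2 (beyond the scatter), so it lowered the measured stabilisation. Compound 3, with the structure `Cn1nc(C(C)(C)C)cc1NC(=O)Nc1cc(F)cc(F)c1`, shares the same urea and the same substituted pyrazole but carries a different aromatic ring on the other side of the urea; how the cores of compound 1 and compound 3 differ is not broken down here. In this assay, going by the values given here, compound 3 gave 1.2 degrees C, and that value and the one for compound 2 lie within the usual scatter of each other, so nothing separates them.

Compound 4, with the structure `CC(C)(C)c1cc(NC(=O)Nc2cc(F)cc(F)c2)n(-c2ccc(F)cc2)n1`, has not yet been measured. It is related to compound 3 by the same change that turns compound 1 into compound 2: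

4-fluorophenyl in place of methyl on an aromatic nitrogen

Among the compounds with values here, because the only measured example of this change is the step of a number 1.9 degrees C lower from compound 1 to compound 2 (beyond the scatter), a drop of similar size is the natural expectation, and the step from compound 3 to compound 4 is therefore estimated as a number 1.7 degrees C lower from compound 3 to compound 4 (beyond the scatter). Since compound 3 starts from a lower value, that puts compound 4 close to zero stabilisation. The expected value for compound 4 in this assay is -0.5 degrees C, with a plausible range from -1.6 degrees C to 0.7 degrees C; this rests on a single precedent and should be read with that caution.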

Compound 4, shift of the target's melting temperature: 2.7 degrees C
Compound 4: middle estimate off by 3.2 degrees C, on the low side; the whole stated range lies below it.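

In this assay, the same swap of methyl for 4-fluorophenyl on the aromatic nitrogen now gives a number 1.5 degrees C higher from compound 3 to compound 4 (beyond the scatter), so the earlier drop did not carry over to the core of compound 3. The two results point in opposite directions, and the gap between them is larger than the scatter alone would explain: the same change on two cores in this assay, a number 1.9 degrees C lower (beyond the scatter) from compound 1 to compound 2 and a number 1.5 degrees C higher (beyond the scatter) from compound 3 to compound 4, 3.4 degrees C apart, beyond the scatter of two such steps This shows that, in this series, the effect of the swap depends on the aromatic ring on the other side of the urea, so one step measured on one core is a poor guide to the same step on another; it does not show why the direction reverses, and two pairs of compounds give no rule for predicting what a third core would do.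

The compounds shown leave open how the swap behaves when that aromatic ring carries other groups, such as a nitrile or an amine, which would show whether the reversal is particular to these two rings. They also leave open whether other groups on the aromatic nitrogen, such as an unsubstituted phenyl or a longer chain, would follow the methyl or the 4-fluorophenyl on each core.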